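Naphthyl-to-dichlorophenyl swap on the pyrazole sulfonamide

This account rests on a few compounds, and the source may have more. Where it says the series, first, only, none or still open, it means among the compounds named here.

Working notes on a small set of sulfonamides tested in a functional assay on HeLa cells for antagonist activity at 5-hydroxytryptamine receptor 6 (Homo sapiens), read by HTRF and cAMP accumulation, with stated times of 10 min and 30 min; a lower number here means a stronger inhibitor, a higher number a weaker inhibitor. Compound 1 `O=C1c2[nH]nc(NS(=O)(=O)c3ccc4ccccc4c3)c2CCN1CC1CCNCC1` is the lactam-fused entry with a piperidinylmethyl side chain; in this assay compound 1 gives 310 nM. Compound 2 `CC(C)Cc1cc(CNS(=O)(=O)Cc2cccc3ccccc23)nn1-c1ccccc1` carries the naphthylmethyl sulfonyl group on the pyrazole scaffold, but in this assay compound 2 is recorded as "not determined" (no result reported), so no number is available for it. Compound 3 `CC(C)Cc1cc(CNS(=O)(=O)c2ccc3ccccc3c2)nn1-c1ccccc1` is the naphthalen-2-yl sulfonamide on the same pyrazole scaffold; in this assay compound 3 gives 3300 nM. Of the two numbers available, compound 3 is the higher one and compound 1 the lower, a gap that lies beyond the scatter; the two compounds differ in more than one place, so no single step can be read from them.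

Compound 4 `CC(C)Cc1cc(CNS(=O)(=O)c2c(Cl)cccc2Cl)nn1-c1ccccc1` is the next entry: 2,6-dichlorophenyl in place of naphthalen-2-yl on a sulfonyl sulfur. For the measured compounds named here, no step between measured compounds bears on this change, so the expectation rests on compound 3 alone. A modest rise in the number is expected, though one that may sit close to the scatter, giving an expected step of a 1.5-fold higher number from compound 3 to compound 4 (0.18 log units; within the scatter). In this assay compound 4 is estimated at 5000 nM, with a likely range from 1500 nM to 20000 nM.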

Compound 4, half-maximal inhibitory concentration: 5650 nM
Compound 4: the middle estimate sits 1.1-fold (0.05 log units) below what was measured, within the range that was stated.
By their numbers in this assay, from the lowest: compound 1; then compounds 3 and 4 (each within the scatter of the next).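

For the compounds shown here, on a sulfonyl sulfur whose other neighbours are the sulfonamide nitrogen, this is the first change that can be read in a single place: in this assay, 2,6-dichlorophenyl in place of naphthalen-2-yl gives a 1.7-fold higher number from compound 3 to compound 4 (0.23 log units; within the scatter). The two values cannot be told apart, so on this scaffold a group with one six-membered aromatic ring of carbon only reads the same as one with 2 six-membered aromatic rings of carbon only, at least for this pair, and the chlorine atoms bring no separation either. No measured data bear on why the two groups read alike.

On these data alone, compound 1 differs from both pyrazole sulfonamides in more than one place, so whether a change on this sulfonyl sulfur alone could bring the scaffold close to compound 1 at 310 nM remains open. Also open is how this position would respond to a group of another kind, such as a methoxy-substituted phenyl, a primary amine or a carboxylic acid, since the pair shown covers only naphthalen-2-yl and 2,6-dichlorophenyl.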